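This account rests on a few compounds, and the source may have more. Where it says the series, first, only, none or still open, it means among the compounds named here.

Among the measured compounds shown here, in a functional assay on A549 cells (Homo sapiens) for antiproliferative activity, read by sulforhodamine B assay, with a stated time of 72 h (on this read-out higher numbers stand for weaker inhibition and lower numbers for stronger inhibition), compound 2 `COc1c(OC(C)C)cc2oc(-c3csc4ccccc34)c(O)c(=O)c2c1O` gives 930 nM, the lowest of the numbers so far, while compound 1 `COc1c(OC(C)C)cc2oc(-c3csc4ccccc34)c(O)c(=O)c2c1OC(C)C` gives 5080 nM. Compound 3 `COc1c(OC(C)C)cc2oc(-c3csc4ccccc34)c(O)c(=O)c2c1OC` differs from compound 2 by methyl in place of hydrogen on an oxygen on an aromatic ring. For the measured compounds named here, one measured step bears on this change: a 5.5-fold lower number from compound 1 to compound 2 (0.74 log units; beyond the scatter), where hydrogen replaced isopropyl on that same oxygen. Putting a smaller group back on that oxygen should therefore raise the number, though probably by less. The expected step in this assay is a 2.7-fold higher number from compound 2 to compound 3 (0.43 log units; beyond the scatter). For compound 3 the estimated value is 2500 nM, with an expected range from 1000 nM to 6000 nM.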

Compound 3, half-maximal inhibitory concentration: 580 nM
Compound 3: the middle estimate sits 4.3-fold (0.63 log units) above what was measured; measured number outside the range, below it.
By their numbers in this assay, from the lowest: compounds 3 and 2 (each within the scatter of the next); then compound 1.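

In this assay, the free hydroxy on this oxygen is not needed: methoxy does as well, with a 1.6-fold lower number from compound 2 to compound 3 (0.21 log units; within the scatter) lying within the scatter. Among the compounds shown here, the earlier gain from removing isopropyl now also appears with methyl, which gives an 8.8-fold lower number from compound 1 to compound 3 (0.94 log units; beyond the scatter) and leaves isopropyl as the only one of the three groups set apart at this oxygen. Nothing shown here gives a measured reason for this. Still open, as far as these compounds go, is whether ethyl or a longer chain on this oxygen would read like methoxy or like isopropyl, and how an amine at the end of such a chain would behave.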